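This account rests on a few compounds, and the source may have more. Where it says the series, first, only, none or still open, it means among the compounds named here.

Three measured compounds share one core and differ only in the group on the far ring. Compound 1 `Clc1ccc(/C=N/Nc2nc3ccccc3s2)cc1` in a functional assay on MDA-MB-435 cells (Homo sapiens) for cytotoxicity, read by MTT assay, with a stated time of 72 h (a lower number here means a stronger inhibitor, a higher number a weaker inhibitor), shows only a limit, > 17300 nM. Compound 2 `CN(C)c1ccc(/C=N/Nc2nc3ccccc3s2)cc1` likewise gives only a limit in this assay, > 16800 nM. Compound 3 `Brc1ccc(/C=N/Nc2nc3ccccc3s2)cc1` also reaches only a limit in this assay, > 15000 nM. So compound 3 stands nowhere readable among the numbers shown: all three values are limits, and the steps a step that the two limits leave unreadable from compound 1 to compound 2, a step that the two limits leave unreadable from compound 1 to compound 3 and a step that the two limits leave unreadable from compound 2 to compound 3 cannot be sized. Compound 4 `C(=N/Nc1nc2ccccc2s1)\c1ccc(-c2ccccn2)cc1` arises through (pyridin-2-yl in place of bromo on an aromatic carbon). Going by the values given here, no measured step bears on a change of this kind, and none of the three measured groups gave a number rather than a limit. Compound 4 is expected to give about 20000 nM, between 8000 nM and 60000 nM. This estimate means an expected step that the limit leaves unreadable from compound 3 to compound 4.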

Compound 4, half-maximal inhibitory concentration: > 15100 nM
Compound 4 was reported as a limit; the forecaster's own chance of this, stated with the estimate: 75%; the middle value lies beyond the limit too.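

Going by these compounds alone, compound 4, like compounds 1, 2 and 3, gives only a limit in this assay, so no step between compound 4 and any of them can be read. The compounds shown leave open whether changing the group on the far ring alters the result at all.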